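The source may report more compounds than this note shows. Statements on the series, on what has been measured and on what is new or still open speak of the compounds shown alone.

Compound 1 `C[C@H](NC(=O)Nc1ccccc1F)c1ccccc1` and compound 2 `C[C@@H](NC(=O)Nc1cccc(F)c1)c1ccccc1` contain the same atoms joined differently; how the two cores differ is not broken down here. In an ADME assay on the whole organism with Oryza sativa as the target, tested at 0.1 uM (on this read-out lower numbers stand for a stronger effect and higher numbers for a weaker effect at the one concentration tested), compound 1 gives 98%, and compound 2 gives 99%; these two numbers lie within the usual scatter of each other. Compound 3 `C[C@H](NC(=O)Nc1ccc(F)cc1F)c1ccccc1` carries, relative to compound 1, (fluoro in place of hydrogen on an aromatic carbon). That change gives a number 3 percentage points higher from compound 1 to compound 3 (within the scatter), and compound 3 stands at 101%. Compound 4 `C[C@@H](NC(=O)Nc1cc(F)cc(F)c1)c1ccccc1` has not yet been measured; it relates to compound 2 through (fluoro in place of hydrogen on an aromatic carbon), the same kind of change, except that here the entering fluoro sits meta to a large group rather than para to it. Because the earlier step of a number 3 percentage points higher from compound 1 to compound 3 (within the scatter) stayed within the scatter, the step from compound 2 to compound 4 is expected to be a number 1 percentage points higher from compound 2 to compound 4 (within the scatter). Compound 4 is accordingly estimated at 100%, with a likely range from 91% to 109%.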

Compound 4, a percentage reported as activity, at one concentration (the size of the read-out at that concentration, not a potency): 98%
Estimate against measurement, compound 4: 2 percentage points above; low and high end bracket the measured number.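

Replacing a hydrogen on an aromatic carbon with fluoro gives, in this assay, a number 1 percentage points lower from compound 2 to compound 4 (within the scatter). Set beside the earlier example, the change gives results on the two cores that cannot be told apart: the same change on two cores in this assay, a number 3 percentage points higher (within the scatter) from compound 1 to compound 3 and a number 1 percentage points lower (within the scatter) from compound 2 to compound 4, 4 percentage points apart, within the scatter of two such steps. Going by these compounds alone, this shows no sign that the core alters the outcome of this change, but it does not show that the change carries over in any useful sense, since neither step can be told from the scatter, and the comparison rests on only two cores at a single concentration.

Within the data shown here, the only group entering the aromatic rings here is fluoro. As far as these compounds go, whether a chlorine atom, a methoxy group or a carboxylic acid would shift this read-out on either core remains open.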